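Triazene series: methyl in place of cyano, buffer half-life

This account rests on a few compounds, and the source may have more. Where it says the series, first, only, none or still open, it means among the compounds named here.

Compound 3, `CN(/N=N/c1ccc(C#N)cc1)C(=O)NCCSc1ccc(O)cc1`, stands at a limit in a physicochemical assay for pharmacokinetics, read by HPLC, in phosphate buffer, at pH 7.4; a higher number here means that the compound lasts longer, a lower number that the compound disappears faster: in this assay compound 3 gives > 240 h, a limit of the assay and not a number. Compound 1, `CCOC(=O)c1ccc(/N=N/N(C)C(=O)NCCSc2ccc(O)cc2)cc1`, gives > 240 h in this assay, likewise a limit. Compound 2, `CC(=O)c1ccc(/N=N/N(C)C(=O)NCCSc2ccc(O)cc2)cc1`, gives > 240 h, also a limit. the limit of > 240 h in this assay, at which 3 of the 3 values shown sit, shows all three values at one limit. The steps a step that the two limits leave unreadable from compound 1 to compound 2, a step that the two limits leave unreadable from compound 1 to compound 3 and a step that the two limits leave unreadable from compound 2 to compound 3 are therefore of unreadable size; none of them carries a value away from the limit. Compound 4, `Cc1ccc(/N=N/N(C)C(=O)NCCSc2ccc(O)cc2)cc1`, differs from compound 3 by methyl in place of cyano on an aromatic carbon. Among the measured compounds shown here, no measured step introduces a methyl on this aromatic carbon; the three measured steps, each exchanging the group on an aromatic carbon of the same ring, bear on the change only in showing that none of these exchanges pulls the half-life below the limit. The expected step from compound 3 is thus a step that the limit leaves unreadable from compound 3 to compound 4, no readable change. Compound 4 is estimated at 300 h, between 150 h and 600 h, most likely again reported as a limit.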

Compound 4, half-life: > 240 h
Compound 4 ended at the assay's limit; the forecaster's own chance of this, stated with the estimate: 85%; the middle value is on the limit's open side.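

In this assay, among the compounds shown here, no step among compound 1, compound 2, compound 3 and compound 4 can be read, because each value is a limit of the assay and not a number: the limit of > 240 h in this assay, at which 4 of the 4 values shown sit. The compounds shown leave open how long any of them actually lasts, and whether the exchanged groups differ in half-life at all.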